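The source may hold more compounds than are shown below. What is called first, only, known or untested is meant among the compounds shown, and "the series" means these compounds.

Series notes. Compound 1 `O=C(c1ccccc1)c1sc(N2CCCCC2)nc1-c1ccccc1` is the reference point. In an assay for inhibition of Polyunsaturated fatty acid 5-lipoxygenase (Homo sapiens), read by spectrophotometry, tested at 10 uM (a higher number here means more inhibition at the concentration tested (going by the name of the read-out), a lower number less inhibition), compound 1 gives 85.2%. The only other measured member, compound 2 `O=C(c1ccccc1)c1sc(N2CCCC2)nc1-c1ccccc1`, gives 75.3% in this assay, and the single measured step, a number 9.9 percentage points lower from compound 1 to compound 2 (within the scatter), concerns the amine ring alone and lies within the scatter, so compound 1 and compound 2 sit together on the numbers shown.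

Compound 3 `COc1ccc(-c2nc(N3CCCCC3)sc2C(=O)c2ccccc2)cc1` is not yet measured. It differs from compound 1 by methoxy in place of hydrogen on an aromatic carbon. Going by the values given here, no measured step touches the phenyl ring, so the step from compound 1 to compound 2 gives no direct guide to this change; it shows only that one substituent swap on the shared core left the read-out within the scatter. For compound 3 the expected step in this assay is therefore a number 3.2 percentage points lower from compound 1 to compound 3 (within the scatter), none beyond the scatter. Compound 3 is estimated at 82% in this assay, with a range from 62% to 95%.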

Compound 3, a percentage reported as inhibition, at one concentration (the size of the read-out at that concentration, not a potency): 62%
Compound 3: the middle estimate sits 20 percentage points above what was measured, and the stated range covers the measured number.
By their numbers in this assay, from the lowest: compound 3; then compounds 2 and 1 (each within the scatter of the next).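

Phenyl to 4-methoxyphenyl gives a number 23.2 percentage points lower from compound 1 to compound 3 (beyond the scatter) in this assay and is the only step in the series that lies beyond the scatter. The aryl ring of the shared core is therefore a place where a small substituent moves the read-out, whereas the amine ring swap from piperidin-1-yl to pyrrolidin-1-yl gave a number 9.9 percentage points lower from compound 1 to compound 2 (within the scatter) and did not separate its two compounds. No evidence at hand explains the drop with methoxy.

From the compounds shown here alone, a single substituent at a single place cannot show whether the drop belongs to methoxy itself or to any group there, so hydroxy, fluoro, chloro or a longer ether such as ethoxy at that carbon remain open. Also open, going by these compounds, are the other positions on this ring and whether the drop would recur with the pyrrolidin-1-yl amine.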